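The compounds below may be only part of what the source reports. "The series", "measured", "known", "first", "only" and "open" are said of these compounds alone.

Working notes on a small series of dichloropurine benzyl compounds tested in a functional assay on SW-620 cells (Homo sapiens) for cytotoxicity, read by sulforhodamine B assay, with a stated time of 48 h; a higher number here means a weaker inhibitor of growth, a lower number a stronger inhibitor of growth.

Compound 1 `ClCc1ccccc1Cn1cnc2c(Cl)nc(Cl)nc21` gives 350 nM in this assay. Compound 2 `ClCc1cccc(Cn2cnc3c(Cl)nc(Cl)nc32)c1` shares the same atoms joined differently; the difference between the two cores is not broken down here. In this assay compound 2 gives 3460 nM, which stands above compound 1 and below compound 3. Compound 3 `Nc1nc(Cl)c2ncn(Cc3ccccc3CCl)c2n1` carries the change amino in place of chloro on an aromatic carbon and gives 11800 nM in this assay, so the step of a 34-fold higher number from compound 1 to compound 3 (1.53 log units; beyond the scatter) is the single large move seen so far.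

Compound 4 `Nc1nc(Cl)c2ncn(Cc3cccc(CCl)c3)c2n1` is not yet measured. It differs from compound 2 by amino in place of chloro on an aromatic carbon, which is the same change as that from compound 1 to compound 3, at a place described in identical words in both cases: on an aromatic carbon of a six-membered aromatic ring with 2 nitrogen, part of a fused or bridged system of two rings, between two ring nitrogen atoms, meta to a chloro group, meta to a fused ring, para to a fused ring. The change occurs twice among the four compounds.

The expectation for compound 4 is a step of about the same size as the earlier one, a 29-fold higher number from compound 2 to compound 4 (1.46 log units; beyond the scatter), because the change from compound 1 to compound 3 gave a 34-fold higher number from compound 1 to compound 3 (1.53 log units; beyond the scatter) and the starting point, compound 2 at 3460 nM, already lies high. Compound 4 is therefore estimated at 100000 nM in this assay, with a range from 30000 nM to 300000 nM; this rests on one prior step only, so a limit rather than a number is possible.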

Compound 4, concentration for total growth inhibition: 11200 nM
For compound 4 the middle estimate is 8.9-fold (0.95 log units) above the measured one; the whole stated range lies above it.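

On the core of compound 2, amino in place of chloro on an aromatic carbon gives a 3.2-fold higher number from compound 2 to compound 4 (0.51 log units; beyond the scatter) in this assay, a modest step, and it runs in the same direction as the step on the core of compound 1. The direction of the change therefore carries from one core to the other in these two pairs, but its size does not, so the step from one core cannot be applied unchanged to the other: the same change on two cores in this assay, a 34-fold higher number (1.53 log units; beyond the scatter) from compound 1 to compound 3 and a 3.2-fold higher number (0.51 log units; beyond the scatter) from compound 2 to compound 4, 10-fold (1.02 log units) apart, beyond the scatter of two such steps

These two pairs do not show why the size of the step depends on the core, nor what the same change would do on any further core, and with one pair per core they give no sense of how much each step would shift if other groups on the core were altered.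

The compounds shown leave open whether a methylamino, dimethylamino or methoxy group in place of that chloro would follow the amino group, and on which core any such difference would appear. They also leave open how either core would respond if the chloromethyl group gave way to a hydroxymethyl group or a longer chain.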